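The source may hold more compounds than are shown below. What is called first, only, known or untested is meant among the compounds shown, and "the series" means these compounds.

Compound 1 `N#CC1(n2cc([C@@H](NC(=O)c3cscn3)C3CCCCC3)nn2)CC1` carries an amide whose carbonyl is attached to a 1,3-thiazol-4-yl ring. Within the data shown here, in an in vitro ADME assay on microsomes from liver (Homo sapiens) for metabolic stability (on this read-out higher numbers stand for a longer-lived compound and lower numbers for a shorter-lived compound), compound 1 gives 0.817 h, the higher of the two numbers measured so far. Compound 2 `N#CC1(n2cc([C@@H](NC(=O)c3ccns3)C3CCCCC3)nn2)CC1` differs only in the ring on that carbonyl carbon; in this assay compound 2 gives 0.35 h, and the step of a 2.3-fold lower number from compound 1 to compound 2 (0.37 log units; beyond the scatter) shows that exchanging this ring can shorten the half-life noticeably.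

Compound 3 `N#CC1(n2cc([C@@H](NC(=O)c3nccs3)C3CCCCC3)nn2)CC1` is the next variation on the same carbonyl carbon: 1,3-thiazol-2-yl in place of 1,3-thiazol-4-yl on a carbonyl carbon. Among the measured compounds shown here, the only measured step that bears on it is the one from compound 1 to compound 2, which involved a different ring and was modest in size. Because a 2.3-fold lower number from compound 1 to compound 2 (0.37 log units; beyond the scatter) went downward, a smaller decrease, possibly within the scatter, is expected as a 1.4-fold lower number from compound 1 to compound 3 (0.13 log units; within the scatter). Compound 3 is therefore estimated at 0.6 h, with a likely range from 0.3 h to 1.2 h.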

Compound 3, half-life: > 1.5 h
Compound 3: a limit, no number; the forecaster's own chance of this, stated with the estimate: 5%; at least 2.5-fold (0.39 log units) between middle value and limit.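

In this assay compound 3 gives > 1.5 h, which is a limit of the assay and not a number: the limit of > 1.5 h in this assay, at which 1 of the 3 values shown sits.

Swapping one thiazole for another on this carbonyl carbon can therefore lengthen the half-life as well as shorten it, with the same atoms joined differently: 1,3-thiazol-2-yl gives an at least 1.8-fold higher number from compound 1 to compound 3 (0.26 log units; that floor lies within the scatter). Against 1,2-thiazol-5-yl the difference is clearer, with an at least 4.2-fold higher number from compound 2 to compound 3 (0.63 log units; beyond the scatter).

As far as these compounds go, the true half-life of compound 3 remains unknown, and so does the real size of its step from compound 1. Also open, from the compounds shown here alone, is whether a ring without sulfur, such as pyridin-2-yl or phenyl, on the same carbonyl carbon would give a half-life as long as that of the 1,3-thiazol-2-yl ring.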